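Dienone Cytotoxicity: Fluoro to Dimethylamino on the Aryl Ring

The compounds below may be only part of what the source reports. "The series", "measured", "known", "first", "only" and "open" are said of these compounds alone.

Measured compounds:
compound 1 `O=C1C=CCC/C1=C\C=C\c1ccc(F)cc1`: 2200 nM
compound 2 `O=C1C=CCC/C1=C\C=C\c1ccccc1[N+](=O)[O-]`: 6200 nM
compound 3 `COc1cc(/C=C/C=C2\CCC=CC2=O)ccc1O`: 900 nM

Three dienones sharing one core were tested in a functional assay on HCT-116 cells (Homo sapiens) for cytotoxicity, read by MTT assay, with a stated time of 72 h; on this read-out higher numbers stand for weaker inhibition and lower numbers for stronger inhibition. Compound 1 gives 2200 nM and stands second highest of the three numbers. Its nearest neighbour is compound 3, which gives 900 nM, a gap beyond the scatter; furthest from it is compound 2, which gives 6200 nM, also beyond the scatter. Compound 3 is thus the strongest inhibitor of the three, compound 2 the weakest.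

The unmeasured compound 4 `CN(C)c1ccc(/C=C/C=C2\CCC=CC2=O)cc1` differs from compound 1 in one place: dimethylamino in place of fluoro on an aromatic carbon. Within the data shown here, no pair of measured compounds shows this exact change, so the size of the step in this assay is not known from the data. With so few compounds, a modest step towards a lower number, of a size comparable to the gap between compound 1 and compound 3, is expected, though a result within the scatter of compound 1 cannot be excluded. For compound 4 the estimate is 1100 nM, with a range of 400 nM to 3200 nM, which means an expected step of a 2.0-fold lower number from compound 1 to compound 4 (0.30 log units; within the scatter).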

Compound 4, half-maximal inhibitory concentration: 1200 nM
The estimate for compound 4 lay 1.1-fold (0.04 log units) below the measured number; the measured number falls inside the stated range.
By their numbers in this assay, from the lowest: compounds 3, 4 and 1 (each within the scatter of the next, the first and the last beyond it); then compound 2.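

In this assay, among these compounds, putting dimethylamino in place of fluoro on an aromatic carbon para to a large group gives a 1.8-fold lower number from compound 1 to compound 4 (0.26 log units; within the scatter), the first step in this set that can be read between two compounds differing in one place. At this position of the shared core, a group of three heavy atoms with one hydrogen-bond acceptor thus replaces a single fluorine without a shift beyond the scatter. Nothing measured here accounts for this result.

This single step leaves open whether a primary amine, a morpholine ring or a carboxylic acid on the same aromatic carbon would also stay within the scatter of compound 1. It also leaves open whether dimethylamino would give a similar result on another carbon of the aromatic ring.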